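The source may report more compounds than this note shows. Statements on the series, on what has been measured and on what is new or still open speak of the compounds shown alone.

Going by the values given here, in a functional assay on A549 cells (Homo sapiens) for inhibition, read by CCK-8 assay (a lower number here means a stronger inhibitor, a higher number a weaker inhibitor), compound 2 `COc1ccc(-c2nnc(CSc3nnc(/N=C/c4ccccc4O)s3)o2)cc1` gives 20300 nM; the only other number comes from compound 1 `Oc1ccccc1/C=N/c1nnc(SCc2nnc(-c3ccc(Cl)cc3)o2)s1`, which gives 30100 nM, and a 1.5-fold lower number from compound 1 to compound 2 (0.17 log units; within the scatter), so the two do not separate. Compound 3 `O=[N+]([O-])c1cccc(-c2nnc(CSc3nnc(/N=C/c4ccccc4O)s3)o2)c1` differs from compound 2 by 3-nitrophenyl in place of 4-methoxyphenyl on an aromatic carbon. Among the compounds with values here, no measured step exchanges one aryl group for another of this kind, and the one step measured stayed within the scatter, so no step beyond the scatter is expected in this assay. Compound 3 is therefore expected to give 22000 nM, between 8000 nM and 60000 nM, which means an expected 1.1-fold higher number from compound 2 to compound 3 (0.03 log units; within the scatter).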

Compound 3, half-maximal inhibitory concentration: 36900 nM
Compound 3: the middle estimate sits 1.7-fold (0.22 log units) below what was measured; the range from low to high includes it.
By their numbers in this assay, from the lowest: compounds 2, 1 and 3 (each within the scatter of the next).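

In this assay the aromatic carbon of the five-membered ring now carries a third aryl group: 3-nitrophenyl in place of 4-methoxyphenyl gives a 1.8-fold higher number from compound 2 to compound 3 (0.26 log units; within the scatter) and 3-nitrophenyl in place of 4-chlorophenyl gives a 1.2-fold higher number from compound 1 to compound 3 (0.09 log units; within the scatter). Aryl groups that differ in their substituent and in its place on the phenyl ring have therefore not separated at this position. Nothing available bears on this result. The compounds shown leave open whether an amine, a carboxylic acid or a longer chain at this position, in place of a substituted phenyl, would give a step beyond the scatter.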